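A few compounds are considered here, and "the series" means these few. Any claim that something is new, unique, unknown or untested is made for them only; others in the source may bear on it.

Measured compounds:
- compound 1, `Nc1cc(N)c2nc(-c3ccccc3)c(NCc3ccc(Cl)c(Cl)c3)nc2c1`: 14100 nM
- compound 2, `CCOC(=O)[C@H](CCC(=O)O)NC(=O)c1ccc(Oc2nc3cc(N)cc(N)c3nc2-c2ccccc2)cc1`: 15500 nM

Two compounds share the core and carry different groups on it. In a functional assay on NCI-H23 cells (Homo sapiens) for inhibition, read by sulforhodamine B assay, with a stated time of 48 h (on this read-out higher numbers stand for weaker inhibition of growth and lower numbers for stronger inhibition of growth), compound 1 gives 14100 nM, and in this assay compound 2 gives 15500 nM. The two numbers sit within the scatter of each other, so on what is shown compound 1 stands together with compound 2, neither separated from the other.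

Compound 3, `COc1ccc(CNc2nc3cc(N)cc(N)c3nc2-c2ccccc2)cc1`, has not been measured in this assay. It differs from compound 1 in one place: 4-methoxyphenyl in place of 3,4-dichlorophenyl on a saturated chain carbon bound to a nitrogen on an aromatic ring. No step between two measured compounds of this kind is shown, and compound 2 differs from compound 1 in another way, so the size of this change has no direct precedent in the data.

With nothing to anchor the step, the expectation is a modest change, with the number for compound 3 expected somewhat higher than that of compound 1, on the edge of the scatter, though a step in either direction would not be surprising. The step from compound 1 to compound 3 is thus estimated as a 1.6-fold higher number from compound 1 to compound 3 (0.19 log units; within the scatter). For compound 3 in this assay the estimate is 22000 nM, with a range from 7000 nM to 70000 nM.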

Compound 3, concentration for 50% growth inhibition: 17000 nM
Beside the measured number, compound 3's estimate is 1.3-fold (0.11 log units) above it, within the range that was stated.
By their numbers in this assay, from the lowest: compounds 1, 2 and 3 (each within the scatter of the next).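

In this assay, among the compounds shown here, the one step read at this position is a 1.2-fold higher number from compound 1 to compound 3 (0.08 log units; within the scatter) and so gives the first direct reading for this exchange: 3,4-dichlorobenzyl and 4-methoxybenzyl are not separated on this read-out. The two groups hold the same 8 heavy atoms but differ in what they contain, with 2 chlorine atoms and 0 hydrogen-bond acceptors in the group that leaves, and 1 oxygen and 1 hydrogen-bond acceptor in the group that enters, and in this single pair that difference does not show up in the number. Nothing on hand bears on why the two groups read alike.

With one pair, the step says nothing about any other group at this place, since both groups compared are substituted phenyl rings on a saturated chain carbon. Open, on these data alone, is whether a ring carrying an amine or a carboxylic acid in place of the 4-methoxyphenyl, a longer chain in place of the single saturated chain carbon, or a plain unsubstituted phenyl would stay with these numbers or move clearly away from them.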